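The source may hold more compounds than are shown below. What is called first, only, known or untested is meant among the compounds shown, and "the series" means these compounds.

Compound 1 `Brc1cccc(COc2nc3ccccc3s2)c1` and compound 3 `Brc1ccc(COc2nc3ccccc3s2)cc1` are built from the same atoms joined differently; the difference between the two cores is not broken down here. In a functional assay on the whole organism with Mus musculus as the target, with a stated time of 1 h, at a dose of 100 mg/kg by the intraperitoneal route (on this read-out higher numbers stand for more inhibition at the one dose given (going by the name of the read-out) and lower numbers for less inhibition), compound 1 gives 77.6%, and compound 3 gives 78%. Compound 2 `Clc1cccc(COc2nc3ccccc3s2)c1` comes from compound 1 by chloro in place of bromo on an aromatic carbon, and in this assay compound 2 gives 80%, a step of a number 2.4 percentage points higher from compound 1 to compound 2 (within the scatter). Compound 4 `Clc1ccc(COc2nc3ccccc3s2)cc1`, not yet measured, comes from compound 3 by chloro in place of bromo on an aromatic carbon. This is the same kind of change as that from compound 1 to compound 2, though here the entering group sits para to a large group, whereas in the earlier pair it sat meta to a large group. Resting on the step of a number 2.4 percentage points higher from compound 1 to compound 2 (within the scatter), which lay within the scatter, the expected step is a number 2 percentage points higher from compound 3 to compound 4 (within the scatter) in this assay. Compound 4 is therefore estimated at 80%, with the likely range running from 70% to 88%.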

Compound 4, a percentage reported as inhibition, in the whole organism at one dose (the size of the read-out at that dose, not a potency): 82.9%
Compound 4: the middle estimate sits 2.9 percentage points below what was measured; measured number inside the range.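

In this assay, chloro in place of bromo on an aromatic carbon gives a number 4.9 percentage points higher from compound 3 to compound 4 (within the scatter), so the same change can now be read on two cores. Set side by side, the two steps do not differ: the same change on two cores in this assay, a number 2.4 percentage points higher (within the scatter) from compound 1 to compound 2 and a number 4.9 percentage points higher (within the scatter) from compound 3 to compound 4, 2.5 percentage points apart, within the scatter of two such steps. This shows that, across these two pairs, the change carries from one core to the other without a gap that stands clear of the scatter; it does not show that chloro and bromo differ in this assay, since each step on its own lies within the scatter, and two pairs say nothing about cores beyond these.

The compounds shown leave open what happens when the halogen gives way to a group of another kind, such as a methoxy group, an amine or a carboxylic acid. They also leave open how these compounds compare at other doses, since every number here is the size of the read-out at one dose and not a potency.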